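Arylsulfonylpiperazine series: aryl to phenylethyl on the piperazine

The compounds below may be only part of what the source reports. "The series", "measured", "known", "first", "only" and "open" are said of these compounds alone.

Measured so far:
compound 1, `CCCn1c(=O)[nH]c2nc(-c3ccc(S(=O)(=O)N4CCN(c5ccccc5Br)CC4)cc3)[nH]c2c1=O`: 0.137 nM
compound 2, `CCCn1c(=O)[nH]c2nc(-c3ccc(S(=O)(=O)N4CCN(c5ccc(Cl)cc5F)CC4)cc3)[nH]c2c1=O`: 1.91 nM
compound 3, `CCCn1c(=O)[nH]c2nc(-c3ccc(S(=O)(=O)N4CCN(Cc5cccc(Br)c5)CC4)cc3)[nH]c2c1=O`: 0.148 nM

All three share one core and differ only in the group on the amine nitrogen in the piperazine ring. In an assay on CHO cells for displacement of a labelled ligand from adenosine receptor A2b (Homo sapiens), read by scintillation counting, with a stated time of 75 min, in the presence of a further agent that is not named here (on this read-out higher numbers stand for weaker inhibition and lower numbers for stronger inhibition), compound 1 gives the lowest number of the three. Its nearest neighbour is compound 3, reached by a 1.1-fold higher number from compound 1 to compound 3 (0.03 log units; within the scatter), so the two cannot be set in order. Compound 2 is the far one, reached by a 14-fold higher number from compound 1 to compound 2 (1.14 log units; beyond the scatter), and the same gap recurs as a 13-fold lower number from compound 2 to compound 3 (1.11 log units; beyond the scatter).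

Compound 4, `CCCn1c(=O)[nH]c2nc(-c3ccc(S(=O)(=O)N4CCN(C(C)c5ccccc5)CC4)cc3)[nH]c2c1=O`, is not yet measured in this assay. The change from compound 1 is 1-phenylethyl in place of 2-bromophenyl on an amine nitrogen in a ring. Within the data shown here, the only step that bears on it is the swap of a directly attached aryl for a benzylic group, a 1.1-fold higher number from compound 1 to compound 3 (0.03 log units; within the scatter), which stayed within the scatter; no measured step removes a halogen altogether, so that part of the change is uncharted. A modest rise in the number is expected, a 2.2-fold higher number from compound 1 to compound 4 (0.34 log units; beyond the scatter), with the uncharted part widening the range.

For compound 4 the expected value in this assay is 0.3 nM, in the range 0.08 nM to 1.2 nM.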

Compound 4, inhibition constant: 8.34 nM
Beside the measured number, compound 4's estimate is 28-fold (1.44 log units) below it; measured number above the stated range.
By their numbers in this assay, from the lowest: compounds 1 and 3 (each within the scatter of the next); then compound 2; then compound 4.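

In this assay, 1-phenylethyl on the amine nitrogen is poorly matched to the low numbers of the two bromine-bearing compounds (a 61-fold higher number from compound 1 to compound 4 (1.78 log units; beyond the scatter); a 56-fold higher number from compound 3 to compound 4 (1.75 log units; beyond the scatter)), and it also lies above the fluorine- and chlorine-bearing compound (a 4.4-fold higher number from compound 2 to compound 4 (0.64 log units; beyond the scatter)). The earlier match between compound 1 and compound 3 therefore does not extend to every aromatic group on this nitrogen. Among these four, the two bromine-bearing groups give the lowest numbers, while compound 2 and compound 4, which lack bromine, give higher ones, but nothing measured here gives a reason for this order.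

Compound 4 differs from compound 3 in both the loss of bromine and the change from benzyl to 1-phenylethyl, so the two contributions cannot be separated. An unsubstituted benzyl group and a bromine-bearing 1-phenylethyl group would be the direct tests, and a 2-phenylethyl group would show whether the longer chain is tolerated.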